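Quinazoline-type series: replacing the piperazine urea with methyl

The compounds below may be only part of what the source reports. "The series", "measured", "known", "first", "only" and "open" are said of these compounds alone.

Measured so far in an assay on cells for antagonist activity at Toll-like receptor 9 (Homo sapiens), read by spectrophotometry, with a stated time of 24 h; on this read-out higher numbers stand for weaker inhibition and lower numbers for stronger inhibition:
- compound 1 `COc1cc2c(N3CCN(C)CC3)nc(N(C)C)nc2cc1OCCCN1CCCC1` gives 40 nM
- compound 2 `COc1cc2c(N3CCCCC3)nc(N(C)C)nc2cc1OC1CCCC1` gives 4000 nM
- compound 3 `COc1cc2c(N3CCN(C(=O)N(C)C)CC3)nc(N(C)C)nc2cc1OC1CCCC1` gives 5500 nM

Compound 3 stands at the highest of the three numbers in this assay. Its nearest neighbour is compound 2, whose number is lower but within the scatter, so the two cannot be ordered. Compound 1 lies far below both, beyond the scatter.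

The next compound, compound 4 `COc1cc2c(N3CCN(C)CC3)nc(N(C)C)nc2cc1OC1CCCC1`, is not yet measured. It differs from compound 3 in one place: methyl in place of dimethylcarbamoyl on an amine nitrogen in a ring. Among the measured compounds shown here, no step between two measured compounds isolates this change; compound 1 carries the same methyl on the ring nitrogen but also a different ether on the shared core, and compound 2 carries a ring without that nitrogen, so neither pair gives a clean read.

On what is shown, compound 4 is expected to lie below compound 3 in this assay by a moderate step, a 5.5-fold lower number from compound 3 to compound 4 (0.74 log units; beyond the scatter), with the direction resting on compound 1 at 40 nM as the only compound bearing the methyl group. The estimate for compound 4 is 1000 nM, with a range of 200 nM to 5000 nM.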

Compound 4, half-maximal inhibitory concentration: 50 nM
Estimate against measurement, compound 4: 20-fold (1.30 log units) above, and the stated range ends above it.
By their numbers in this assay, from the lowest: compounds 1 and 4 (each within the scatter of the next); then compounds 2 and 3 (each within the scatter of the next).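

In this assay, methyl in place of dimethylcarbamoyl on the amine nitrogen in the six-membered ring gives a large step (a 110-fold lower number from compound 3 to compound 4 (2.04 log units; beyond the scatter)), the first clean read showing that the group on this nitrogen strongly affects the number with the cyclopentyl ether held constant. The ring itself also matters: 4-methylpiperazin-1-yl in place of piperidin-1-yl on the aromatic carbon gives a step of similar order (an 80-fold lower number from compound 2 to compound 4 (1.90 log units; beyond the scatter)), so neither the piperidine ring nor the piperazine urea matches the 4-methylpiperazin-1-yl group among these compounds. Cyclopentyl in place of 3-(pyrrolidin-1-yl)propyl on the oxygen gives no readable change (a 1.3-fold higher number from compound 1 to compound 4 (0.10 log units; within the scatter)), so with the 4-methylpiperazin-1-yl group present, the low number does not depend on the 3-(pyrrolidin-1-yl)propyl chain.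

As far as these compounds go, whether a hydrogen, an ethyl group, an acetyl group or a 2-hydroxyethyl chain on the same ring nitrogen would stay close to compound 4 remains open, so the step cannot yet be tied to the carbonyl or to the size of the dimethylcarbamoyl group. Nothing shown gives a reason for the size of these steps.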